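Moving the Fluorine Back on a Pyridine Ring

A few compounds are considered here, and "the series" means these few. Any claim that something is new, unique, unknown or untested is made for them only; others in the source may bear on it.

In a functional assay on MCF7 cells (Homo sapiens) for antiproliferative activity, read by sulforhodamine B assay, with a stated time of 48 h (a higher number here means a weaker inhibitor, a lower number a stronger inhibitor), compound 1 `COc1ccc(/C=C/C(=O)c2ccccc2-c2ccc(F)cc2)cc1OC` gives 240 nM and compound 2 `COc1ccc(/C=C/C(=O)c2ccccc2-c2cccc(F)c2)cc1OC` gives 1200 nM, the higher number of the pair. Compound 2 is therefore the weaker inhibitor of the two. Among the compounds with values here, the only measured step is a 5.0-fold higher number from compound 1 to compound 2 (0.70 log units; beyond the scatter), with 3-fluorophenyl in place of 4-fluorophenyl on an aromatic carbon. It is modest but beyond the usual scatter.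

Compound 3 `COc1ccc(/C=C/C(=O)c2ccccc2-c2ccc(F)nc2)cc1OC` carries 6-fluoropyridin-3-yl in place of 3-fluorophenyl on an aromatic carbon, ortho to a large group: 6-fluoropyridin-3-yl in place of 3-fluorophenyl on an aromatic carbon. In its fluorine placement, 6-fluoropyridin-3-yl resembles 4-fluorophenyl rather than 3-fluorophenyl, so the measured step bears on this change when read in reverse. Within the data shown here, no measured compound carries a ring with a hetero atom, so the effect of that swap in this assay is unknown. Only part of the measured step is therefore expected to be recovered, towards a lower number. The expected change is a 2.2-fold lower number from compound 2 to compound 3 (0.34 log units; beyond the scatter). For compound 3 the estimated value is 550 nM, with an expected range from 180 nM to 1600 nM.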

Compound 3, half-maximal inhibitory concentration: 2800 nM
Beside the measured number, compound 3's estimate is 5.1-fold (0.71 log units) below it, and the stated range ends below it.
By their numbers in this assay, from the lowest: compound 1; then compound 2; then compound 3.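

At this position, ortho to a large group, the earlier pair had shown only that moving the fluorine on a phenyl ring changes the number. Compound 3 shows that the ring itself also counts in this assay: 6-fluoropyridin-3-yl gives a 2.3-fold higher number from compound 2 to compound 3 (0.37 log units; beyond the scatter) and, against the 4-fluorophenyl it resembles in fluorine placement, a 12-fold higher number from compound 1 to compound 3 (1.07 log units; beyond the scatter) so that a fluorine placed as in compound 1 does not by itself keep the lower number once the ring holds a hetero atom. Nothing available explains why this swap raises the number.

The compounds shown leave open whether the rise belongs to the ring nitrogen alone or to the nitrogen and fluorine together, since all three rings carry a fluorine. From the compounds shown here alone, how a plain phenyl, a pyridin-3-yl without fluorine, a chlorine in the fluorine's place or an amine at that same carbon of the pyridine would read in this assay also remains unknown here, and with it whether any ring with a hetero atom can be tolerated at this position.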